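Swapping the Aryl Ether for a Sulfonyl Group

This account rests on a few compounds, and the source may have more. Where it says the series, first, only, none or still open, it means among the compounds named here.

Measured in a physicochemical assay for solubility, read by nephelometry, measured as kinetic solubility, with a stated time of 30 min (a lower number here means a less soluble compound, a higher number a more soluble compound), so far:
Compound 1 `c1cc([C@H]2CC[C@]3(CC2)OOC2(O3)C3CC4CC(C3)CC2C4)ccc1OCCOC1CCNCC1` gives 50 ug/mL
Compound 2 `CC(C)(N)CCOc1ccc([C@H]2CC[C@]3(CC2)OOC2(O3)C3CC4CC(C3)CC2C4)cc1` gives 50 ug/mL
Compound 3 `c1cc([C@H]2CC[C@]3(CC2)OOC2(O3)C3CC4CC(C3)CC2C4)ccc1OC1CCNCC1` gives > 100 ug/mL

The reading for compound 3 of > 100 ug/mL is a limit of the assay and not a number. The next step leads to compound 4 `NC1CCN(S(=O)(=O)c2ccc([C@H]3CC[C@]4(CC3)OOC3(O4)C4CC5CC(C4)CC3C5)cc2)CC1` and puts (4-aminopiperidin-1-yl)sulfonyl in place of (piperidin-4-yl)oxy on an aromatic carbon, para to a large group ((4-aminopiperidin-1-yl)sulfonyl in place of (piperidin-4-yl)oxy on an aromatic carbon). The measured steps that bear on this all alter the group attached through the oxygen: an at least 2.0-fold higher number from compound 1 to compound 3 (0.30 log units; that floor lies within the scatter), an at least 2.0-fold higher number from compound 2 to compound 3 (0.30 log units; that floor lies within the scatter) and no change at the digits printed from compound 1 to compound 2 (within the scatter). None of them removes that oxygen or brings in a sulfonyl group, so they offer only a loose guide. The expectation therefore leans on the numbered readings, compound 1 at 50 ug/mL and compound 2 at 50 ug/mL. The expected step is an at least 1.6-fold lower number from compound 3 to compound 4 (0.22 log units; that floor lies within the scatter), towards a lower number in this assay but possibly not far beyond the scatter. Compound 4 is estimated at 60 ug/mL, with an expected range from 20 ug/mL to 100 ug/mL.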

Compound 4, solubility: 12.5 ug/mL
Compound 4: the middle estimate sits 4.8-fold (0.68 log units) above what was measured, and the stated range ends above it.
By their numbers in this assay, from the lowest: compound 4; then compounds 1 and 2 (each within the scatter of the next). At a limit, above all of these: compound 3.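

In this assay, this is the first change shown that removes the oxygen on the aromatic ring and brings in a sulfonyl group, and it gives an at least 8.0-fold lower number from compound 3 to compound 4 (0.90 log units; beyond the scatter). The comparisons with the two longer ether groups point the same way, with a 4.0-fold lower number from compound 2 to compound 4 (0.60 log units; beyond the scatter) and a 4.0-fold lower number from compound 1 to compound 4 (0.60 log units; beyond the scatter), so this change at the aromatic carbon, unlike the earlier changes to the group on the oxygen, leaves compound 4 lowest of the four. Compound 3 reads > 100 ug/mL, which is a limit of the assay and not a number, so the first of these steps is only a floor: the limit of > 100 ug/mL in this assay, at which 1 of the 4 values shown sits.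

In compound 4 the sulfonyl link and the 4-aminopiperidin-1-yl group enter together, and the compounds shown cannot tell their contributions apart. From the compounds shown here alone, how a carbonyl in place of the sulfonyl, or a simple open-chain amine on the sulfonyl, would read also remains open.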